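Replacing the amide methyl of compound 1 with a five-membered ring

The source may report more compounds than this note shows. Statements on the series, on what has been measured and on what is new or still open speak of the compounds shown alone.

Compound 1 `CNC(=O)[C@H](c1ccc(Cl)cc1)C(C)C`: 11000 nM
Compound 2 `CC(C)[C@H](C(=O)Nc1nncs1)c1ccc(Cl)cc1`: 12000 nM
Compound 3 `CC(C)[C@H](C(=O)Nc1ncc[nH]1)c1ccc(Cl)cc1`: 20000 nM

In a functional assay on CHO cells for agonist activity at Free fatty acid receptor 2 (Homo sapiens), read by cAMP accumulation (a lower number here means a stronger inhibitor, a higher number a weaker inhibitor), compound 1 gives 11000 nM, the lowest of the three numbers. Its nearest neighbour is compound 2 with 12000 nM, a change of a 1.1-fold higher number from compound 1 to compound 2 (0.04 log units; within the scatter); the furthest is compound 3 with 20000 nM, a change of a 1.8-fold higher number from compound 1 to compound 3 (0.26 log units; within the scatter). Both steps lie within the scatter, so the three measured compounds cannot be ranked against one another.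

Compound 4 `CC(C)[C@H](C(=O)NC1=NC(=O)CS1)c1ccc(Cl)cc1` differs from compound 1 in one place: a group of 6 heavy atoms (3 carbon, 1 nitrogen, 1 oxygen, 1 sulfur; one five-membered non-aromatic ring with 2 hetero atoms) in place of one carbon atom, on an amide-type nitrogen.

Among the measured compounds shown here, the steps that bear on this change are those in which the methyl of compound 1 was replaced by another five-membered ring on the same amide-type nitrogen, giving compound 2 and compound 3. Both were small: a 1.1-fold higher number from compound 1 to compound 2 (0.04 log units; within the scatter) and a 1.8-fold higher number from compound 1 to compound 3 (0.26 log units; within the scatter), and the step between those two ring-bearing compounds, a 1.7-fold higher number from compound 2 to compound 3 (0.22 log units; within the scatter), was also within the scatter. On this evidence a third five-membered ring at the same place is expected to leave the number close to that of compound 1, with no step beyond the scatter in either direction. For compound 4 the estimate is 14000 nM, in the range 6000 nM to 35000 nM, which would mean an expected step of a 1.3-fold higher number from compound 1 to compound 4 (0.10 log units; within the scatter).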

Compound 4, half-maximal inhibitory concentration: 20000 nM
Beside the measured number, compound 4's estimate is 1.4-fold (0.15 log units) below it; the range from low to high includes it.
By their numbers in this assay, from the lowest: compounds 1, 2, 3 and 4 (each within the scatter of the next).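

The earlier compounds shown here carried only methyl or a five-membered aromatic ring on this amide-type nitrogen, and compound 4 extends the comparison to a five-membered non-aromatic ring, with a step from the methyl of a 1.8-fold higher number from compound 1 to compound 4 (0.26 log units; within the scatter). Against the aromatic rings the steps are no change at the digits printed from compound 3 to compound 4 (within the scatter) and a 1.7-fold higher number from compound 2 to compound 4 (0.22 log units; within the scatter), so in this assay exchanging either aromatic ring for the non-aromatic one gives no step beyond the scatter, and the four groups at this place still cannot be ranked against one another. No measurement at hand accounts for why such different groups on this nitrogen give numbers within the scatter of one another.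

The compounds shown leave open whether any group at this place can move the number beyond the scatter in either direction. A phenyl ring, a longer chain such as n-butyl or a chain ending in a carboxylic acid on the same amide-type nitrogen would test whether this insensitivity extends beyond methyl and five-membered rings.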